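The compounds below may be only part of what the source reports. "The series", "measured", "known", "first", "only" and "open" are said of these compounds alone.

Measured in an ADME assay on Vero cells (Chlorocebus sabaeus) for cytotoxicity, read by CellTiter-Glo, with a stated time of 72 h; a higher number here means that more compound is tolerated, a lower number that less compound is tolerated:
- compound 1 `[O-][n+]1nc(NC2CCCC2)[n+]([O-])c2ccc(F)cc21`: 2.3 ug/mL
- compound 2 `CCNc1n[n+]([O-])c2cc(Br)ccc2[n+]1[O-]`: 4.2 ug/mL

With only these two measurements, compound 2 at 4.2 ug/mL and compound 1 at 2.3 ug/mL lie within the scatter of each other, so neither stands apart.

Compound 3 `[O-][n+]1nc(NC2CCCC2)[n+]([O-])c2ccc(Br)cc21` follows from compound 2 by one change, cyclopentyl in place of ethyl on a nitrogen on an aromatic ring. Within the data shown here, no step between measured compounds shows what this change does in this assay. The nearest guide is compound 1, which also carries the cyclopentylamino group and gives 2.3 ug/mL. On that basis, a small move towards less compound tolerated is expected, not beyond the scatter: a 1.4-fold lower number from compound 2 to compound 3 (0.15 log units; within the scatter) is the estimated step. For compound 3 the expected value is 3 ug/mL, with an estimated range of 1.3 ug/mL to 6.5 ug/mL.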

Compound 3, half-maximal cytotoxic concentration: 18 ug/mL
Compound 3: middle estimate off by 6.0-fold (0.78 log units), on the low side, and the stated range ends below it.
By their numbers in this assay, from the lowest: compounds 1 and 2 (each within the scatter of the next); then compound 3.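

In this assay, ethylamino to cyclopentylamino with bromo on the aromatic carbon gives a 4.3-fold higher number from compound 2 to compound 3 (0.63 log units; beyond the scatter), so cyclopentyl on this nitrogen does not by itself keep the number low. The halogen counts as well: with cyclopentylamino kept, bromo in place of fluoro gives a 7.8-fold higher number from compound 1 to compound 3 (0.89 log units; beyond the scatter), which shows that the fluoro compound was a poor guide to the effect of cyclopentyl alongside bromo. Nothing available here bears on the reason for either step.

From the compounds shown here alone, each change rests on a single pair, so it remains open whether cyclopentyl in place of ethyl would also raise the number with fluoro on the aromatic carbon. Also open, going by these compounds, is how chloro on that carbon, or a cyclohexyl group or a longer chain ending in an amine on the nitrogen, would read.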